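Adding a Chloro Group to the Anilino Part of Compound 1

This account rests on a few compounds, and the source may have more. Where it says the series, first, only, none or still open, it means among the compounds named here.

Measured so far in a functional assay on HCT-116 cells (Homo sapiens) for antiproliferative activity, read by CCK-8 assay, with a stated time of 72 h, tested at 2 uM; on this read-out lower numbers stand for a weaker effect and higher numbers for a stronger effect at the one concentration tested: compound 1, `Nc1ccccc1NC(=O)c1ccc(Cn2cnc3c(Nc4ccccc4)nc(Cl)nc32)cc1`, gives 71.4%; compound 2, `CCCCn1cnc2c(NCc3ccc(C(=O)Nc4ccccc4N)cc3)nc(Cl)nc21`, gives 4.89%; compound 3, `CC(C)n1cnc2c(NCc3ccc(C(=O)Nc4ccccc4N)cc3)nc(Cl)nc21`, gives 73.2%.

Compound 1 stands second highest of the three numbers. Its value and that of compound 3 lie within the usual scatter of each other, while compound 2 sits far lower. For the measured compounds named here, the only step between measured compounds, a number 68.3 percentage points higher from compound 2 to compound 3 (beyond the scatter), concerns the group on the aromatic nitrogen and leaves the anilino part untouched.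

Compound 4, `Nc1ccccc1NC(=O)c1ccc(Cn2cnc3c(Nc4cccc(Cl)c4)nc(Cl)nc32)cc1`, differs from compound 1 in one place: chloro in place of hydrogen on an aromatic carbon. Going by the values given here, no measured step bears on this change, so the data offer no guide to its effect. In this assay a step of no size beyond the scatter is expected, a number 3.4 percentage points lower from compound 1 to compound 4 (within the scatter). Compound 4 is therefore estimated at 68%, with a range from 45% to 85%.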

Compound 4, a percentage reported as inhibition, at one concentration (the size of the read-out at that concentration, not a potency): 56.2%
Compound 4: the middle estimate sits 11.8 percentage points above what was measured; the range from low to high includes it.
By their numbers in this assay, from the lowest: compound 2; then compound 4; then compounds 1 and 3 (each within the scatter of the next).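

The anilino part of the molecule responds to substitution: in this assay, chloro in place of hydrogen on an aromatic carbon, meta to a large group, gives a number 15.2 percentage points lower from compound 1 to compound 4 (beyond the scatter). For the compounds shown here, this is the first measured step at this part of the molecule, as the earlier step concerned only the group on the aromatic nitrogen. No measurement at hand accounts for this step.

The compounds shown leave open whether the lower number belongs to chloro alone or would follow any added group at this place, as fluoro, methyl or methoxy on the same carbon would show.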